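The compounds below may be only part of what the source reports. "The series", "measured", "known", "first", "only" and "open" are said of these compounds alone.

Values in a functional assay on the whole organism with Rattus norvegicus as the target; on this read-out lower numbers stand for an effect already at smaller amounts and higher numbers for an effect only at larger amounts of compound:
Compound 1 `CCCn1c(=N)sc2cc(OC(F)(F)F)ccc21`: 4.5 mg/kg
Compound 2 `CN(C)S(=O)(=O)CCn1c(=N)sc2cc(OC(F)(F)F)ccc21`: > 10 mg/kg, a limit
Compound 3 `CCCSCCn1c(=N)sc2cc(OC(F)(F)F)ccc21`: 2.4 mg/kg

Compound 3 stands level with compound 1, with a 1.9-fold lower number from compound 1 to compound 3 (0.27 log units; within the scatter). Against the limit of compound 2, the step is an at least 4.1-fold lower number from compound 2 to compound 3 (0.61 log units; beyond the scatter).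

Compound 4 `N=c1sc2cc(OC(F)(F)F)ccc2n1CC[S+]([O-])c1ccccc1` changes the same place: a group of 8 heavy atoms (6 carbon, 1 oxygen, 1 sulfur; one six-membered aromatic ring of carbon only) in place of a group of 4 heavy atoms (3 carbon, 1 sulfur; no ring), on a saturated chain carbon, two bonds along the chain from an aromatic nitrogen.

For the measured compounds named here, two measured steps bear on it, a 1.9-fold lower number from compound 1 to compound 3 (0.27 log units; within the scatter) and an at least 2.2-fold higher number from compound 1 to compound 2 (0.34 log units; beyond the scatter). One replacement at this place thus left the number within the scatter, while another raised it. Going by the values given here, no measured compound carries a ring in this group, so the outcome is uncertain. The expected change in this assay is a modest rise, a 2.1-fold higher number from compound 3 to compound 4 (0.32 log units; beyond the scatter). For compound 4 the estimate is 5 mg/kg, with an expected range of 1.8 mg/kg to 15 mg/kg.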

Compound 4, dose for half-maximal effect: 4.2 mg/kg
Compound 4: middle estimate off by 1.2-fold (0.08 log units), on the high side, and the stated range covers the measured number.
By their numbers in this assay, from the lowest: compounds 3, 4 and 1 (each within the scatter of the next). At a limit, above all of these: compound 2.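

A group with one six-membered aromatic ring of carbon only does not separate from the smaller groups at this place in this assay: the readings are a 1.8-fold higher number from compound 3 to compound 4 (0.24 log units; within the scatter) and a 1.1-fold lower number from compound 1 to compound 4 (0.03 log units; within the scatter). Compound 2 alone stays apart, with an at least 2.3-fold lower number from compound 2 to compound 4 (0.37 log units; beyond the scatter), and its value is a limit: the limit of > 10 mg/kg in this assay, at which 1 of the 4 values shown sits.

From the compounds shown here alone, compound 4 brings the ring and the oxygen on sulfur in a single change, and their separate shares remain open. Also open, going by these compounds, is how an amine or a carboxylic acid on this chain would read.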